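This account rests on a few compounds, and the source may have more. Where it says the series, first, only, none or still open, it means among the compounds named here.

Compound 1 `N#C/C(=C\c1cc(O)c(O)c([N+](=O)[O-])c1)C(=O)Nc1cccc(Cl)c1` — > 100 ug/mL
Compound 2 `COc1c(O)ccc(/C=C(\C#N)C(=O)Nc2cccc(Cl)c2)c1[N+](=O)[O-]` — > 100 ug/mL
Compound 3 `COc1cc(/C=C(\C#N)C(=O)Nc2cccc(Cl)c2)cc([N+](=O)[O-])c1O` — 26.1 ug/mL

All three were tested in a functional assay on BGC-823 cells (Homo sapiens) for antiproliferative activity, read by MTT assay; a higher number here means a weaker inhibitor, a lower number a stronger inhibitor. For compound 1 the value > 100 ug/mL is only a limit of the assay, not a number. Compound 2 also sits at a limit, > 100 ug/mL. Compound 3 gives a measured number, 26.1 ug/mL. Going by the values given here, the only single-point step here, an at least 3.8-fold lower number from compound 1 to compound 3 (0.58 log units; beyond the scatter), changes an oxygen substituent on the aromatic ring, and it is read against (the limit of > 100 ug/mL in this assay, at which 2 of the 3 values shown sit).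

Compound 4 `N#C/C(=C\c1cc(O)c(O)c([N+](=O)[O-])c1)C(=O)N1CCOCC1` changes a different place: morpholin-4-yl in place of (3-chlorophenyl)amino on a carbonyl carbon. No measured step touches this position, so nothing shown predicts the direction or size of its effect. Since compound 1 itself stands at the limit (the limit of > 100 ug/mL in this assay, at which 2 of the 3 values shown sit), compound 4 is expected to remain a weak inhibitor, with the step of a number no higher from compound 1 to compound 4 (the limit leaves the size open) estimated as small. The estimate for compound 4 is 100 ug/mL, ranging from 40 ug/mL to 300 ug/mL.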

Compound 4, half-maximal inhibitory concentration: > 100 ug/mL
Compound 4 gave a limit, no number (the forecaster's own chance of this, stated with the estimate: 65%); the middle value sits exactly at the limit.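

Going by these compounds alone, compound 1 and compound 4 both stand at a limit, not at a number, so no step between them can be read: the limit of > 100 ug/mL in this assay, at which 3 of the 4 values shown sit.

On these data alone, how morpholin-4-yl and (3-chlorophenyl)amino on the carbonyl carbon compare in strength stays open.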